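Adding a Second Chloro Group to an Inactive Series

The compounds below may be only part of what the source reports. "The series", "measured", "known", "first", "only" and "open" are said of these compounds alone.

Compound 1 `Cn1c(SCc2ccccc2)nnc1-c1cc([N+](=O)[O-])cc([N+](=O)[O-])c1`, compound 2 `Cn1c(SCc2ccc(Cl)cc2)nnc1-c1cc([N+](=O)[O-])cc([N+](=O)[O-])c1` and compound 3 `O=[N+]([O-])c1cc(-c2nnc(SCc3ccc(Cl)cc3)n2Cc2ccccc2)cc([N+](=O)[O-])c1` were each tested in an ADME assay on A-431 cells (Homo sapiens) for cytotoxicity, with a stated time of 48 h; on this read-out lower numbers stand for stronger inhibition and higher numbers for weaker inhibition. Compound 1 reaches only the limit of the assay, > 30000 nM. Compound 2 likewise gives only the limit, > 30000 nM. Compound 3 also stops at the limit, > 30000 nM. The change from compound 1 to compound 2 is chloro in place of hydrogen on an aromatic carbon, and a step that the two limits leave unreadable from compound 1 to compound 2; similarly, a step that the two limits leave unreadable from compound 2 to compound 3. The difference between the cores of compound 1 and compound 3 is not broken down here. Compound 4 `O=[N+]([O-])c1cc(-c2nnc(SCc3ccc(Cl)c(Cl)c3)n2Cc2ccccc2)cc([N+](=O)[O-])c1` carries the same kind of change relative to compound 3, (chloro in place of hydrogen on an aromatic carbon), though here the place is ortho to a chloro group and meta to a large group, whereas in compound 2 it is para to a large group. Because (the limit of > 30000 nM in this assay, at which 3 of the 3 values shown sit), the expected step is a step that the limit leaves unreadable from compound 3 to compound 4. Compound 4 is therefore expected to show 45000 nM in this assay.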

Compound 4, half-maximal inhibitory concentration: > 30000 nM
Compound 4 ended at the assay's limit; the forecaster's own chance of this, stated with the estimate: 80%; the middle value does not contradict the limit.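

No step can be read between compound 3 and compound 4, because both stop at a limit: the limit of > 30000 nM in this assay, at which 4 of the 4 values shown sit.

The compounds shown leave open whether the added chloro group changes anything in this assay, and how any of the four truly ranks there.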